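From acetyl to (piperidin-1-yl)methyl in compound 3

A few compounds are considered here, and "the series" means these few. Any claim that something is new, unique, unknown or untested is made for them only; others in the source may bear on it.

- Compound 1 `O=C1NCCC12CCN(c1c(Cl)cncc1-c1ccco1)CC2`: 940 nM
- Compound 2 `O=C1NCCC12CCN(c1c(Cl)cncc1-c1ccsc1)CC2`: 190 nM
- Compound 3 `CC(=O)c1ccc(-c2cncc(Cl)c2N2CCC3(CCNC3=O)CC2)s1`: 1440 nM

These numbers come from a functional assay on MV4-11 cells (Homo sapiens) for inhibition, read by resazurin assay, with a stated time of 72 h; on this read-out lower numbers stand for stronger inhibition of growth and higher numbers for weaker inhibition of growth. Compound 3 stands level with compound 1 within the scatter, as a 1.5-fold higher number from compound 1 to compound 3 (0.19 log units; within the scatter) shows, and clearly apart from compound 2, as a 7.6-fold higher number from compound 2 to compound 3 (0.88 log units; beyond the scatter) shows.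

Compound 4 `O=C1NCCC12CCN(c1c(Cl)cncc1-c1ccc(CN3CCCCC3)s1)CC2` has (piperidin-1-yl)methyl in place of acetyl on an aromatic carbon. For the measured compounds named here, no measured step makes this exact swap. The closest guides change the same aromatic group: a 4.9-fold lower number from compound 1 to compound 2 (0.69 log units; beyond the scatter) and a 7.6-fold higher number from compound 2 to compound 3 (0.88 log units; beyond the scatter). Only a modest move is therefore expected, tentatively towards a lower number. The expected change is a 2.4-fold lower number from compound 3 to compound 4 (0.38 log units; beyond the scatter). For compound 4 the estimated value is 600 nM, with an expected range from 150 nM to 2400 nM.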

Compound 4, concentration for 50% growth inhibition: 4010 nM
For compound 4 the middle estimate is 6.7-fold (0.82 log units) below the measured one; measured number outside the range, above it.
By their numbers in this assay, from the lowest: compound 2; then compounds 1 and 3 (each within the scatter of the next); then compound 4.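

In this assay the change of acetyl to (piperidin-1-yl)methyl gives a 2.8-fold higher number from compound 3 to compound 4 (0.44 log units; beyond the scatter) and so moves towards weaker inhibition of growth. The earlier steps shown here swapped the whole aromatic group, whereas this one changes only the group on the carbon next to the ring sulfur, and that change alone moves the number beyond the scatter. Nothing available explains the rise.

Still open, from the compounds shown here alone, is how an open-chain amine such as dimethylaminomethyl, or a carboxylic acid, would behave at this place. The two groups shown also cannot tell whether the ring of the piperidine or its nitrogen matters more here.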